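The source may report more compounds than this note shows. Statements on the series, on what has been measured and on what is new or still open speak of the compounds shown alone.

Of the compounds shown here, three sharing one core have been measured in a functional assay on PC-3 cells (Homo sapiens) for antiproliferative activity, read by MTT assay, with a stated time of 72 h; a lower number here means a stronger inhibitor, a higher number a weaker inhibitor. Compound 1 `C=CC(=O)Nc1cc2c(N3CCc4ccccc43)ncnc2cc1OC` gives 5940 nM. Compound 2 `C=CC(=O)Nc1cc2c(N3CCc4ccccc43)ncnc2cc1O[C@@H]1CCOC1` gives 2710 nM. Compound 3 `CCN(CC)C/C=C/C(=O)Nc1cc2c(N3CCc4ccccc43)ncnc2cc1OC` gives 3690 nM. Putting oxolan-3-yl in place of methyl on an oxygen on an aromatic ring gave a 2.2-fold lower number from compound 1 to compound 2 (0.34 log units; beyond the scatter), while putting 3-(diethylamino)prop-1-en-1-yl in place of vinyl on a carbonyl carbon gave a 1.6-fold lower number from compound 1 to compound 3 (0.21 log units; within the scatter). Compound 2 thus stands beyond the scatter from compound 1, whereas its number and that of compound 3 lie within the scatter of each other.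

Compound 4 `O=C(/C=C/CN1CCC(CO)CC1)Nc1cc2c(N3CCc4ccccc43)ncnc2cc1O[C@@H]1CCOC1` has not yet been measured. It differs from compound 2 in one place: 3-(4-(hydroxymethyl)piperidin-1-yl)prop-1-en-1-yl in place of vinyl on a carbonyl carbon. Within the data shown here, the only measured step that bears on this change is the one in which an amine-bearing prop-1-en-1-yl group replaced vinyl on the carbonyl carbon, from compound 1 to compound 3, and that step stayed within the scatter. A step of about the same small size is therefore expected here, a 1.4-fold lower number from compound 2 to compound 4 (0.15 log units; within the scatter), not beyond the scatter. In this assay compound 4 is estimated at 1900 nM, with a range from 700 nM to 5000 nM.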

Compound 4, half-maximal inhibitory concentration: 3310 nM
The estimate for compound 4 lay 1.7-fold (0.24 log units) below the measured number; the range from low to high includes it.
By their numbers in this assay, from the lowest: compounds 2, 4, 3 and 1 (each within the scatter of the next, the first and the last beyond it).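

In this assay, the change on the carbonyl carbon now has a second reading: with oxolan-3-yl rather than methyl on the oxygen, vinyl gave way to 3-(4-(hydroxymethyl)piperidin-1-yl)prop-1-en-1-yl, a group of 11 heavy atoms with a six-membered non-aromatic ring, and the outcome was a 1.2-fold higher number from compound 2 to compound 4 (0.09 log units; within the scatter), so no real shift. Until now, the only such replacement was a 1.6-fold lower number from compound 1 to compound 3 (0.21 log units; within the scatter), which carried a diethylamino group and a methyl on the oxygen, so the absence of a clear shift now holds for two different amine-bearing chains on two different oxygen substituents. Nothing available here accounts for this result.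

The compounds shown leave open whether a different end group on this chain, such as a carboxylic acid or a morpholine, or a longer chain between the double bond and the amine, would move the number beyond the scatter. They also leave open whether the same holds with a longer chain, such as 2-methoxyethyl, in place of oxolan-3-yl on the oxygen.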